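A few compounds are considered here, and "the series" means these few. Any claim that something is new, unique, unknown or untested is made for them only; others in the source may bear on it.

Measured in a functional assay on KB cells (Homo sapiens) for cytotoxicity, read by MTT assay, with a stated time of 72 h; a higher number here means that more compound is needed for the effect, a lower number that less compound is needed:
- Compound 1 `CCOc1c(-c2occ(C)c2C(=O)O)ccc2c(CC)cccc12` reads > 10 ug/mL, which is a limit of the assay.
- Compound 2 `CCOC(=O)c1c(C)coc1-c1ccc2c(CC)cccc2c1OC` reads 2.2 ug/mL.
- Compound 3 `CCc1cccc2c(OC(C)=O)c(-c3occ(C)c3COC(C)=O)ccc12` reads > 10 ug/mL, which is a limit of the assay.

Of these three, only compound 2 has a true number, 2.2 ug/mL. The other two readings give no number, and the series therefore shows (the limit of > 10 ug/mL in this assay, at which 2 of the 3 values shown sit). Among the measured compounds shown here, with only one numerical value, no ranking of the three can be drawn from these data.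

The step of interest leads to compound 4 `CCc1cccc2c(OC)c(-c3occ(C)c3COCC(F)(F)F)ccc12`, which has not yet been measured in this assay. It carries (2,2,2-trifluoroethoxy)methyl in place of ethoxycarbonyl on an aromatic carbon of a five-membered aromatic ring with 1 oxygen ((2,2,2-trifluoroethoxy)methyl in place of ethoxycarbonyl on an aromatic carbon). For the measured compounds named here, no measured pair isolates this change, so any forecast has compound 2 at 2.2 ug/mL as its only numerical anchor.

A moderate shift toward more compound being needed is expected, and a reading at the limit of the assay would not be a surprise. The expected change is a 2.3-fold higher number from compound 2 to compound 4 (0.36 log units; beyond the scatter). For compound 4 the estimated value is 5 ug/mL, with an expected range from 1.8 ug/mL to 12 ug/mL.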

Compound 4, concentration for half-maximal effect: 6.6 ug/mL
For compound 4 the middle estimate is 1.3-fold (0.12 log units) below the measured one, and the stated range covers the measured number.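

In this assay, the place on an aromatic carbon of a five-membered aromatic ring with 1 oxygen now has its first readable step, as (2,2,2-trifluoroethoxy)methyl in place of ethoxycarbonyl gives a 3.0-fold higher number from compound 2 to compound 4 (0.48 log units; beyond the scatter). Compound 4 has lost ethoxycarbonyl, with its double bond outside aromatic rings, and still gives 6.6 ug/mL, so a true number in this assay does not depend on that group at this place, although more compound is needed for the effect. Compound 1 and compound 3 each remain a limit of the assay, and the true numbers in the series are still few: the limit of > 10 ug/mL in this assay, at which 2 of the 4 values shown sit.

This single step changes the heavy atoms of the group in several ways at once, and it cannot tell whether the loss of the carbonyl, the arrival of fluorine or the larger size of the group accounts for the shift. As far as these compounds go, a plain ethoxymethyl group without fluorine, or an amide at the same place, would begin to separate these changes, and both remain open here.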